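A few compounds are considered here, and "the series" means these few. Any claim that something is new, unique, unknown or untested is made for them only; others in the source may bear on it.

Working notes on an ADME assay on Caco-2 cells (Homo sapiens) for permeability, read by LC-MS, in the apical to basolateral direction, with a stated time of 60 min, at pH 6.5; a higher number here means that the compound crosses the layer faster, a lower number that the compound crosses the layer more slowly: compound 1 `O=C(NCc1cc(Cl)ccc1-n1cnnn1)[C@@H]1CC=NN1C(=O)[C@H](O)c1ccccc1` gives 7 10^-6 cm/s, compound 2 `CC1(C[C@@H](O)C(=O)N2N=CC[C@H]2C(=O)NCc2cc(Cl)ccc2-n2cnnn2)CC1` gives 9.5 10^-6 cm/s, and compound 3 `O=C(O[C@@H](C(=O)N1N=CC[C@H]1C(=O)NCc1cc(Cl)ccc1-n1cnnn1)c1ccc(F)cc1)c1ccccc1` gives 43 10^-6 cm/s. Compound 2 is within the scatter of compound 1 and beyond the scatter from compound 3, which has the highest number of the three.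

Next is compound 4 `CC(C)CC[C@@H](O)C(=O)N1N=CC[C@H]1C(=O)NCc1cc(Cl)ccc1-n1cnnn1`: isobutyl in place of 1-methylcyclopropyl on a saturated chain carbon, two bonds along the chain from a carbonyl carbon and an oxygen on a saturated carbon. In words, isobutyl stands in place of 1-methylcyclopropyl on a saturated chain carbon, two bonds along the chain from a carbonyl carbon and an oxygen on a saturated carbon.

Among the compounds with values here, the one measured step bearing on this place, a 1.4-fold higher number from compound 1 to compound 2 (0.13 log units; within the scatter), with (1-methylcyclopropyl)methyl in place of phenyl, lies within the scatter. No step beyond the scatter is therefore expected in this assay.

The expected change is a 1.1-fold higher number from compound 2 to compound 4 (0.02 log units; within the scatter).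

For compound 4 the estimated value is 10 10^-6 cm/s, with an expected range of 5 10^-6 cm/s to 20 10^-6 cm/s.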

Compound 4, apparent permeability: 29 10^-6 cm/s
The estimate for compound 4 lay 2.9-fold (0.46 log units) below the measured number; the whole stated range lies below it.
By their numbers in this assay, from the lowest: compounds 1 and 2 (each within the scatter of the next); then compounds 4 and 3 (each within the scatter of the next).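

In this assay this position responds to the change: isobutyl in place of 1-methylcyclopropyl, with the same number of heavy atoms and no ring, gives a 3.1-fold higher number from compound 2 to compound 4 (0.48 log units; beyond the scatter) and so goes beyond the scatter, unlike the earlier step at this place. Isopentyl in place of phenyl gives a 4.1-fold higher number from compound 1 to compound 4 (0.62 log units; beyond the scatter) and also goes beyond the scatter. Here the open-chain group stands apart from both ring-bearing groups.

From the compounds shown here alone, whether a longer chain, or an amine or a carboxylic acid at the chain end, would extend or reverse this remains open. Nothing at hand says what lies behind these steps.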